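The source may hold more compounds than are shown below. What is called first, only, known or untested is meant among the compounds shown, and "the series" means these compounds.

Measured so far:
compound 1, `Nc1scc(CN2CCN(c3ccc(OC(F)(F)F)cc3)CC2)c1C(=O)c1ccc(Cl)cc1`, -74%
compound 2, `Nc1scc(CN2CCN(c3ccccc3F)CC2)c1C(=O)c1ccc(Cl)cc1`, -15%
compound 3, `Nc1scc(CN2CCN(c3ccc(F)cc3F)CC2)c1C(=O)c1ccc(Cl)cc1`, -82%

All three were tested in a functional assay on CHO cells with adenosine receptor A1 (Homo sapiens) as the target, read by cAMP accumulation and immunoassay, with a stated time of 6 min, tested at 10 uM (on this read-out lower numbers stand for a stronger effect and higher numbers for a weaker effect at the one concentration tested), where compound 3 gives the lowest of the three numbers. Its neighbour on the numbers is compound 1, with a number 8 percentage points lower from compound 1 to compound 3 (within the scatter), so these two cannot be told apart; the step of a number 67 percentage points lower from compound 2 to compound 3 (beyond the scatter), by contrast, is a large one.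

Compound 4, `Nc1scc(CN2CCN(c3cc(Cl)ccc3Cl)CC2)c1C(=O)c1ccc(Cl)cc1`, has not yet been measured. It differs from compound 3 in one place: 2,5-dichlorophenyl in place of 2,4-difluorophenyl on an amine nitrogen in a ring. Among the measured compounds shown here, none of the measured steps swaps fluorine for chlorine or moves a halogen on this ring, so no step bears directly on the change. What the data do show is that a single fluorine on the phenyl gives a weak number in compound 2, while two substituents give strong numbers in compound 1 and compound 3. The estimate for compound 4 therefore leans toward the strong side but with wide uncertainty: -60%, within -95% to -15%, which is an expected step of a number 22 percentage points higher from compound 3 to compound 4 (beyond the scatter).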

Compound 4, a percentage reported as activity, at one concentration (the size of the read-out at that concentration, not a potency): -62%
Compound 4: the middle estimate sits 2 percentage points above what was measured; measured number inside the range.
By their numbers in this assay, from the lowest: compounds 3 and 1 (each within the scatter of the next); then compound 4; then compound 2.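

Chlorine appears on this phenyl for the first time here, and the 2,5-dichlorophenyl group keeps much of the strong effect in this assay (a number 47 percentage points lower from compound 2 to compound 4 (beyond the scatter)). Even so, compound 4 does not quite reach the two strongest compounds (a number 20 percentage points higher from compound 3 to compound 4 (beyond the scatter); a number 12 percentage points higher from compound 1 to compound 4 (beyond the scatter)), and both of these gaps are modest. The group on this amine nitrogen therefore need not contain fluorine for a strong effect, but this swap changes both the halogen and its place on the phenyl, so the two changes cannot be separated.

Going by these compounds, it remains open whether a phenyl bearing a methoxy group or a nitrile would hold the effect as well. Nothing available here explains why the numbers move at this position.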